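Cyclohexylmethyl in Place of Ethoxycarbonyl: What to Expect

A few compounds are considered here, and "the series" means these few. Any claim that something is new, unique, unknown or untested is made for them only; others in the source may bear on it.

Measured so far:
- Compound 1 `NCCNC(=S)Nc1ccnc2cc(Cl)ccc12`: in a functional assay on HeLa cells (Homo sapiens) for cytotoxicity, read by MTT assay, with a stated time of 7 h (a higher number here means a weaker inhibitor, a lower number a stronger inhibitor), compound 1 gives 18000 nM.
- Compound 2 `CCN1CCN(C(=S)Nc2ccnc3cc(Cl)ccc23)CC1`: in this assay compound 2 gives > 50000 nM, which is a limit of the assay rather than a number.
- Compound 3 `CCOC(=O)N1CCN(C(=S)Nc2ccnc3cc(Cl)ccc23)CC1`: in this assay compound 3 gives 40100 nM.

Of the two numbers, compound 3 has the highest; compound 1 sits below it by a gap beyond the usual scatter. Compound 2 is known only as a limit (the limit of > 50000 nM in this assay, at which 1 of the 3 values shown sits).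

Compound 4 `S=C(Nc1ccnc2cc(Cl)ccc12)N1CCN(CC2CCCCC2)CC1` has not yet been measured. It differs from compound 3 in one place: cyclohexylmethyl in place of ethoxycarbonyl on an amine nitrogen in a ring. Among the compounds with values here, only one measured step touches the same ring nitrogen, an at least 1.2-fold lower number from compound 2 to compound 3 (0.09 log units; that floor lies within the scatter), where ethoxycarbonyl replaced ethyl and the step may be small enough to lie within the scatter. Within the data shown here, no measured step involves cyclohexylmethyl, so the evidence for the present change is thin. Starting from compound 3, compound 4 is expected to give 25000 nM, with a range from 8000 nM to 80000 nM. This estimate means an expected step of a 1.6-fold lower number from compound 3 to compound 4 (0.21 log units; within the scatter), not clearly beyond the scatter.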

Compound 4, half-maximal inhibitory concentration: > 50000 nM
Compound 4 gave a limit, no number; the forecaster's own chance of this, stated with the estimate: 30%; at least 2.0-fold (0.30 log units) between middle value and limit.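

Placing cyclohexylmethyl on this ring nitrogen in place of ethoxycarbonyl gives an at least 1.2-fold higher number from compound 3 to compound 4 (0.09 log units; that floor lies within the scatter). Within the data shown here, this is the first measured sign that a large group made of carbon only, carrying a ring of its own, brings no gain at this position in this assay, though the true size of the step remains unknown. Compound 4 gives a limit of the assay and not a number, a result it shares with compound 2: the limit of > 50000 nM in this assay, at which 2 of the 4 values shown sit.

Going by these compounds, the step from compound 2 to compound 4 cannot be read, and how far either compound lies past the limit stays unknown. On these data alone, it also remains open whether a smaller group on this ring nitrogen, such as acetyl, or a chain ending in a hydroxyl or a free amine, would give a lower number than compound 3.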